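The source may hold more compounds than are shown below. What is called first, only, known or untested is meant among the compounds shown, and "the series" means these compounds.

Working notes on the series. Compound 1 `CN1CCN(c2ccc(Nc3ncc(F)c(NC4CCCC4)n3)cc2)CC1` gives the highest of the two numbers recorded so far: in a functional assay on HeLa cells (Homo sapiens) for cytotoxicity, read by MTT assay, with a stated time of 48 h (on this read-out lower numbers stand for stronger inhibition and higher numbers for weaker inhibition), compound 1 gives 20000 nM, while compound 2 `COc1cc(C(=O)NC2CCN(C)CC2)ccc1Nc1ncc(Cl)c(NC2CCCC2)n1` gives 2700 nM in this assay, a gap that lies beyond the usual scatter. Going by the values given here, no single-change step links these two. Compound 3 `CCCNc1nc(Nc2ccc(N3CCN(C)CC3)cc2)ncc1F` differs from compound 1 by propyl in place of cyclopentyl on a nitrogen on an aromatic ring. With nothing measured on this change, the step is expected to be small, most likely toward a weaker read-out, a 1.5-fold higher number from compound 1 to compound 3 (0.18 log units; within the scatter), and possibly not beyond the scatter. Compound 3 is estimated at 30000 nM in this assay, within 10000 nM to 90000 nM.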

Compound 3, half-maximal inhibitory concentration: 14200 nM
For compound 3 the middle estimate is 2.1-fold (0.32 log units) above the measured one, and the stated range covers the measured number.
By their numbers in this assay, from the lowest: compound 2; then compounds 3 and 1 (each within the scatter of the next).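

In this assay, going by these compounds alone, propyl in place of cyclopentyl on a nitrogen on an aromatic ring gives (a 1.4-fold lower number from compound 1 to compound 3 (0.15 log units; within the scatter)), the first single-change reading at this position. In this pair, the open propyl chain and the five-membered carbon ring therefore read alike within the scatter, so the ring is not needed to hold this level of read-out. Nothing measured here gives a cause for the step. Going by these compounds, whether a benzyl group, a hydroxyethyl group or a longer chain on this nitrogen would move the number beyond the scatter remains open. Also open, on these data alone, is whether the same change would read alike on the core of compound 2.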